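Fluoro in Place of Methyl: Expected Cytotoxicity of Compound 4

The source may report more compounds than this note shows. Statements on the series, on what has been measured and on what is new or still open speak of the compounds shown alone.

Measured compounds:
compound 1 `COc1ccc(Oc2nc(Nc3ccc(C#N)cc3)nc3ccccc23)cc1` gives 340000 nM in an ADME assay on MT4 cells (Homo sapiens) for cytotoxicity, read by MTT assay, with a stated time of 4 days; on this read-out lower numbers stand for higher toxicity in this test and higher numbers for lower toxicity in this test
compound 2 `N#Cc1ccc(Nc2nc(Oc3ccc(Cl)cc3)c3ccccc3n2)cc1` gives 198000 nM in this assay
compound 3 `Cc1ccc(Oc2nc(Nc3ccc(C#N)cc3)nc3ccccc23)cc1` gives 87000 nM in this assay

Compound 3 stands lowest of the three, that is, most toxic here: the steps are a 3.9-fold lower number from compound 1 to compound 3 (0.59 log units; beyond the scatter) and a 2.3-fold lower number from compound 2 to compound 3 (0.36 log units; beyond the scatter), while a 1.7-fold lower number from compound 1 to compound 2 (0.23 log units; within the scatter) separates the other two. Compound 4 `N#Cc1ccc(Nc2nc(Oc3ccc(F)cc3)c3ccccc3n2)cc1` differs from compound 3 only by fluoro in place of methyl on an aromatic carbon. The step that bears most closely on this change is the chloro-to-methyl swap, a 2.3-fold lower number from compound 2 to compound 3 (0.36 log units; beyond the scatter), since fluoro and chloro both stand in for the same methyl; the methoxy swap, a 3.9-fold lower number from compound 1 to compound 3 (0.59 log units; beyond the scatter), points the same way. A modest upward step, a 2.0-fold higher number from compound 3 to compound 4 (0.29 log units; within the scatter), is therefore expected for compound 4. Compound 4 is estimated to give 170000 nM, in the range 70000 nM to 400000 nM.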

Compound 4, half-maximal cytotoxic concentration: > 351000 nM
Compound 4: a limit, no number; the forecaster's own chance of this, stated with the estimate: 20%; middle value at least 2.0-fold (0.31 log units) away from the limit.
By their numbers in this assay, from the lowest: compound 3; then compounds 2 and 1 (each within the scatter of the next). At a limit, above all of these: compound 4.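

Compound 4 reads as a limit of this assay, not as a number: the limit of > 351000 nM in this assay, at which 1 of the 4 values shown sits. The change from 4-methylphenoxy to 4-fluorophenoxy gives an at least 4.0-fold higher number from compound 3 to compound 4 (0.60 log units; beyond the scatter) and so shows that this one position can carry the read-out from the lowest number shown to that limit. On these data alone, the steps of an at least 1.7-fold higher number from compound 2 to compound 4 (0.24 log units; that floor lies within the scatter) and an at least 1.0-fold higher number from compound 1 to compound 4 (0.01 log units; that floor lies within the scatter) have floors within the scatter, so the true distance of compound 4 from those two compounds stays unknown. As far as these compounds go, how an amine or a trifluoromethyl group on this same carbon would read remains open.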